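Changing the amide heteroaryl of compound 1

The compounds below may be only part of what the source reports. "The series", "measured", "known", "first", "only" and "open" are said of these compounds alone.

Compound 1 `O=C(NCc1ccc(S(=O)(=O)N2CCCCC2)cc1)c1cnc2nccn2c1` gives 64% in an ADME assay on microsomes from liver (Homo sapiens) for metabolic stability, read by LC-MS, with a stated time of 30 min, tested at 1 uM (on this read-out lower numbers stand for a less stable compound and higher numbers for a more stable compound), the highest of the three numbers seen here. Compound 3 `O=C(NCc1ccc(S(=O)(=O)c2ccccc2)cc1)c1cnc2nccn2c1`, with phenyl in place of piperidin-1-yl on the sulfonyl sulfur, gives 60%, and the step of a number 4 percentage points lower from compound 1 to compound 3 (within the scatter) lies within the scatter, so these two cannot be ordered. Compound 2 `O=C(NCc1ccc(S(=O)(=O)c2cccc(C(F)(F)F)c2)cc1)c1cnc2nccn2c1`, with 3-(trifluoromethyl)phenyl on the sulfonyl sulfur, gives 41%; the steps of a number 23 percentage points lower from compound 1 to compound 2 (beyond the scatter) and a number 19 percentage points higher from compound 2 to compound 3 (beyond the scatter) are the only ones beyond the scatter, and both are modest. Compound 4 `O=C(NCc1ccc(S(=O)(=O)N2CCCCC2)cc1)c1ccc2nc[nH]c2c1` differs from compound 1 at the carbonyl carbon: a group of 9 heavy atoms (7 carbon, 2 nitrogen; one five-membered aromatic ring with 2 hetero atoms, one six-membered aromatic ring of carbon only) in place of a group of 9 heavy atoms (6 carbon, 3 nitrogen; one five-membered aromatic ring with 2 hetero atoms, one six-membered aromatic ring with 2 hetero atoms), on a carbonyl carbon. Among the compounds with values here, no measured step touches that part of the molecule; all three vary only the group on the sulfonyl sulfur. With nothing bearing directly on this change, the expectation is that compound 4 stays near compound 1, with an expected step of a number 9 percentage points lower from compound 1 to compound 4 (within the scatter) and a wide range around it. The estimate for compound 4 in this assay is 55%, expected to fall between 30% and 80%.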

Compound 4, percent of the compound remaining: 53%
Compound 4: middle estimate off by 2 percentage points, on the high side, and the stated range covers the measured number.
By their numbers in this assay, from the lowest: compound 2; then compounds 4, 3 and 1 (each within the scatter of the next, the first and the last beyond it).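

Within the data shown here, this is the first result at the carbonyl carbon, and it shows that the group there matters in this assay and not only the group on the sulfonyl sulfur: 1H-benzimidazol-6-yl in place of the original heteroaryl gives a number 11 percentage points lower from compound 1 to compound 4 (beyond the scatter). The step is modest, and it comes with the same count of heavy atoms but with one nitrogen exchanged for carbon, a hydrogen-bond donor gained and fewer hydrogen-bond acceptors. Nothing in the data accounts for the step or ties it to any one of these differences.

As far as these compounds go, it remains open whether a simpler group on the carbonyl carbon, such as phenyl or pyridin-3-yl, would give a similar number, or whether placing a methyl on the benzimidazole nitrogen would alter it. From the compounds shown here alone, it is also open whether the step would hold with phenyl rather than piperidin-1-yl on the sulfonyl sulfur.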